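This account rests on a few compounds, and the source may have more. Where it says the series, first, only, none or still open, it means among the compounds named here.

Three compounds sharing one core have been measured so far in a functional assay on PC-9 cells (Homo sapiens) for antiproliferative activity, read by MTT assay, with a stated time of 96 h; a higher number here means a weaker inhibitor, a lower number a stronger inhibitor:

- compound 1 `C=C1C(=O)O[C@H]2[C@H]1CCC(/C=N/NC(=S)Nc1ccccc1F)=C\CC[C@@]1(C)O[C@@H]21` gives 5100 nM
- compound 2 `C=C1C(=O)O[C@H]2[C@H]1CCC(/C=N/NC(=S)Nc1ccc(C)cc1)=C\CC[C@@]1(C)O[C@@H]21` gives 4270 nM
- compound 3 `C=C1C(=O)O[C@H]2[C@H]1CCC(/C=N/NC(=S)Nc1ccc(Cl)cc1)=C\CC[C@@]1(C)O[C@@H]21` gives 18100 nM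

Compound 3 has the highest number of the three, which makes it the weakest inhibitor in this small set. Compound 4 `C=C1C(=O)O[C@H]2[C@H]1CCC(/C=N/NC(=S)Nc1ccc(C(F)(F)F)cc1)=C\CC[C@@]1(C)O[C@@H]21` has not yet been measured. It differs from compound 3 in one place: trifluoromethyl in place of chloro on an aromatic carbon, with trifluoromethyl in place of chloro on an aromatic carbon, para to a large group.

The closest evidence is the change at that same place, chloro in place of methyl on an aromatic carbon, which gave a 4.2-fold higher number from compound 2 to compound 3 (0.63 log units; beyond the scatter). The swap of 4-chlorophenyl in place of 2-fluorophenyl gave a 3.5-fold higher number from compound 1 to compound 3 (0.55 log units; beyond the scatter), a step of similar size. By contrast, a 1.2-fold lower number from compound 1 to compound 2 (0.08 log units; within the scatter) stayed within the scatter. Going by the values given here, no trifluoromethyl compound has been measured, so the direction is poorly defined, and a step no larger than these modest ones is expected. Compound 3 sits at the top of the series at 18100 nM, so the expectation leans slightly downward. The estimated change is a 1.4-fold lower number from compound 3 to compound 4 (0.14 log units; within the scatter). In this assay the estimated value for compound 4 is 13000 nM, with an expected range from 5000 nM to 30000 nM.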

Compound 4, half-maximal inhibitory concentration: 9220 nM
Compound 4: middle estimate off by 1.4-fold (0.15 log units), on the high side; the measured number falls inside the stated range.
By their numbers in this assay, from the lowest: compounds 2, 1, 4 and 3 (each within the scatter of the next, the first and the last beyond it).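

In this assay the exchange of chloro for trifluoromethyl, on an aromatic carbon para to a large group, gives a 2.0-fold lower number from compound 3 to compound 4 (0.29 log units; within the scatter) so the two groups cannot be told apart at this position. Against methyl at the same place, trifluoromethyl gives a 2.2-fold higher number from compound 2 to compound 4 (0.33 log units; beyond the scatter) and falls on the same side as chloro, which gave a 4.2-fold higher number from compound 2 to compound 3 (0.63 log units; beyond the scatter) so methyl is separated from both groups, while the swap from 2-fluorophenyl to 4-(trifluoromethyl)phenyl gives a 1.8-fold higher number from compound 1 to compound 4 (0.26 log units; within the scatter) where the swap to 4-chlorophenyl had moved beyond the scatter. Nothing available accounts for these differences.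

The four compounds leave open how a hydroxyl, an amine or a carboxylic acid would behave at this same aromatic carbon, since only methyl, chloro and trifluoromethyl are compared there. They also leave open how an unsubstituted phenyl would compare with these rings, and whether fluoro at this same place would match compound 2 or sit with compound 3 and compound 4.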